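Cytotoxicity at the Limit Across Three Anilides

A few compounds are considered here, and "the series" means these few. Any claim that something is new, unique, unknown or untested is made for them only; others in the source may bear on it.

Compound 1 `Cc1ccccc1NC(=O)c1ccc2cccc(O)c2n1`, compound 2 `Cc1cccc(NC(=O)c2ccc3cccc(O)c3n2)c1` and compound 3 `O=C(Nc1cccc(F)c1)c1ccc2cccc(O)c2n1` share one core and differ only in the group on the amide nitrogen. In an ADME assay on THP-1 cells (Homo sapiens) for cytotoxicity, read by WST assay, with a stated time of 24 h (on this read-out lower numbers stand for stronger inhibition and higher numbers for weaker inhibition), compound 1 gives > 30000 nM, a limit of the assay rather than a number. Compound 2 likewise gives > 30000 nM, again a limit. Compound 3 gives > 30000 nM, also a limit. The steps a step that the two limits leave unreadable from compound 1 to compound 2, a step that the two limits leave unreadable from compound 1 to compound 3 and a step that the two limits leave unreadable from compound 2 to compound 3 therefore have no readable size, and the whole of the evidence is the limit of > 30000 nM in this assay, at which 3 of the 3 values shown sit. Compound 4 `O=C(Nc1cccc(Br)c1)c1ccc2cccc(O)c2n1` differs from compound 3 by bromo in place of fluoro on an aromatic carbon. Since every measured value sits at that limit, no step beyond the scatter is expected here. Compound 4 is estimated at 40000 nM, between 15000 nM and 100000 nM. The expected step is a step that the limit leaves unreadable from compound 3 to compound 4, most likely another limit.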

Compound 4, half-maximal inhibitory concentration: > 30000 nM
Compound 4: only a limit was reported; the forecaster's own chance of this, stated with the estimate: 85%; the middle value is on the limit's open side.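

Compound 4 also gives only a limit, so its steps from compound 1, compound 2 and compound 3 cannot be read: the limit of > 30000 nM in this assay, at which 4 of the 4 values shown sit. From the compounds shown here alone, how these four compounds rank in this assay stays open, since none has a measured number.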